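Adding a bromine to a diarylamine melatonin ligand

The compounds below may be only part of what the source reports. "The series", "measured", "known", "first", "only" and "open" are said of these compounds alone.

Of the compounds shown here, three have been measured in an assay on NIH3T3 cells for displacement of a labelled ligand from melatonin receptor type 1B (Homo sapiens); a higher number here means a weaker inhibitor, a lower number a stronger inhibitor. Compound 1 `COc1ccc(N(CCNC(C)=O)c2ccccc2)cc1` gives 27.5 nM. Compound 2 `COc1cccc(N(CCNC(C)=O)Cc2ccccc2)c1` gives 0.759 nM. Compound 3 `CC(=O)NCCN(c1ccccc1)c1ccccc1` gives 3.89 nM, the second highest of the three numbers; its nearest neighbour is compound 2, whose number is lower, and the furthest is compound 1, whose number is higher. Within the data shown here, the only step between two measured compounds that differ in one place is a 7.1-fold lower number from compound 1 to compound 3 (0.85 log units; beyond the scatter).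

Compound 4 `CC(=O)NCCN(c1ccccc1)c1cccc(Br)c1` has not yet been measured in this assay. It differs from compound 3 in one respect: bromo in place of hydrogen on an aromatic carbon. Among the measured compounds shown here, none of the measured compounds carries a bromine, and the single measured step concerns the loss of a methoxy rather than the gain of a new group, so it bears on this change only loosely: it shows that one substituent on one of these rings can move the number beyond the scatter. For the measured compounds named here, with no closer precedent, the direction of the change is open. For compound 4 a step of a 1.3-fold lower number from compound 3 to compound 4 (0.11 log units; within the scatter) is expected, which could fall either way. The estimate for compound 4 is 3 nM, with a range from 0.6 nM to 15 nM.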

Compound 4, inhibition constant: 0.2 nM
Compound 4: the middle estimate sits 15-fold (1.18 log units) above what was measured; the whole stated range lies above it.
By their numbers in this assay, from the lowest: compound 4; then compound 2; then compound 3; then compound 1.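

In this assay, bromo in place of hydrogen on an aromatic carbon, meta to a large group, gives a 19-fold lower number from compound 3 to compound 4 (1.29 log units; beyond the scatter) and so makes a much stronger inhibitor with the addition of just 1 heavy atom. Among these compounds, the only earlier step between compounds differing in one place, a 7.1-fold lower number from compound 1 to compound 3 (0.85 log units; beyond the scatter), came from removing a methoxy, so it showed only that a substituent on one of these rings can weaken inhibition; this new step shows that a substituent on such a ring can also strengthen it, and by a large margin. No measurement available here explains why this single bromine has so large an effect.

The compounds shown leave open whether this gain belongs to bromine itself or would also appear with another group on the same carbon, such as a chlorine, a methyl or a methoxy. They also leave open whether a bromine on a different carbon of this ring, or a second bromine on the other aromatic ring, would lower the number further, leave it unchanged or raise it.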